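Swapping isopropyl for cyclopentyl on the aromatic nitrogen

The compounds below may be only part of what the source reports. "The series", "measured", "known", "first", "only" and "open" are said of these compounds alone.

Measured in a functional assay on HCC827 cells (Homo sapiens) for antiproliferative activity, read by MTT assay, with a stated time of 72 h; a lower number here means a stronger inhibitor, a higher number a weaker inhibitor:
- compound 1 `CN1CCN(c2ccc(Nc3ncc4nc(Sc5ccccc5)n(C5CCOCC5)c4n3)cc2)CC1`: 42.6 nM
- compound 2 `CC(C)n1c(Sc2ccccc2)nc2cnc(Nc3ccc(N4CCN(C)CC4)cc3)nc21`: 290 nM
- compound 3 `CN1CCN(c2ccc(Nc3ncc4nc([S+]([O-])c5ccccc5)n(CC5CC5)c4n3)cc2)CC1`: 838 nM

Compound 2 holds the middle place of the three numbers, above compound 1 and below compound 3, and both gaps lie beyond the usual scatter. The next compound, compound 4 `CN1CCN(c2ccc(Nc3ncc4nc(Sc5ccccc5)n(C5CCCC5)c4n3)cc2)CC1`, replaces its isopropyl with cyclopentyl on an aromatic nitrogen: cyclopentyl in place of isopropyl on an aromatic nitrogen.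

Among the measured compounds shown here, one measured step bears on this change. It swaps oxan-4-yl for isopropyl on that same nitrogen, and it is a 6.8-fold higher number from compound 1 to compound 2 (0.83 log units; beyond the scatter). Compound 3 differs from compound 2 in more than one place, so it offers no clean comparison. Cyclopentyl brings back a ring, as oxan-4-yl has, but it is made of carbon only, and no measurement here separates the ring from the rest of oxan-4-yl. A partial return toward compound 1 therefore seems likely in this assay, with a lower number than compound 2 but not as low as compound 1.

The expected change is a 2.4-fold lower number from compound 2 to compound 4 (0.38 log units; beyond the scatter).

For compound 4 the estimated value is 120 nM, with an expected range of 40 nM to 350 nM.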

Compound 4, half-maximal inhibitory concentration: 51.2 nM
The estimate for compound 4 lay 2.3-fold (0.37 log units) above the measured number; measured number inside the range.
By their numbers in this assay, from the lowest: compounds 1 and 4 (each within the scatter of the next); then compound 2; then compound 3.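

In this assay, among the compounds shown here, cyclopentyl in place of isopropyl on the aromatic nitrogen gives a 5.7-fold lower number from compound 2 to compound 4 (0.75 log units; beyond the scatter), which is the first direct sign that a carbon-only ring can do much better here than an open branched group. Cyclopentyl in place of oxan-4-yl gives a 1.2-fold higher number from compound 1 to compound 4 (0.08 log units; within the scatter), so the two rings cannot be told apart in this assay, and the oxygen of oxan-4-yl is not needed to reach numbers this low. Nothing measured here explains why these groups differ as they do.

Compound 2 and compound 4 differ both in the ring and in the number of carbons, and an open pentan-3-yl chain on this nitrogen would be needed to separate the two. From the compounds shown here alone, how a ring carrying an amine, such as piperidin-4-yl, would behave at this position also remains open.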